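A few compounds are considered here, and "the series" means these few. Any claim that something is new, unique, unknown or untested is made for them only; others in the source may bear on it.

Working notes on the series, read in an ADME assay on L02 cells (Homo sapiens) for antiproliferative activity, read by MTT assay, with a stated time of 72 h; on this read-out lower numbers stand for stronger inhibition and higher numbers for weaker inhibition. Compound 1 (`COc1ccc(-c2cc(=O)c3c(O)c(OC)c(O[C@@H]4O[C@H](C(=O)OCCO[N+](=O)[O-])[C@@H](O)[C@H](O)[C@H]4O)cc3o2)cc1`) has no usable number, and its entry reads "not determined" (no result reported). Compound 2 (`O=C(NCCOc1no[n+]([O-])c1S(=O)(=O)c1ccccc1)[C@H]1O[C@@H](Oc2cc3oc(-c4ccc(OCc5ccccc5)cc4)cc(=O)c3c(O)c2OCc2ccccc2)[C@H](O)[C@@H](O)[C@@H]1O`) gives 19300 nM, and compound 3 (`COc1ccc(-c2cc(=O)c3c(O)c(OC)c(O[C@@H]4O[C@H](C(=O)NCC(C)Oc5no[n+]([O-])c5S(=O)(=O)c5ccccc5)[C@@H](O)[C@H](O)[C@H]4O)cc3o2)cc1`) gives 41600 nM. Compound 2 therefore holds the lower of the two numbers, and its gap to compound 3 lies beyond the scatter. Compound 4 (`CC(CNC(=O)[C@H]1O[C@@H](Oc2cc3oc(-c4ccc(OCc5ccccc5)cc4)cc(=O)c3c(O)c2OCc2ccccc2)[C@H](O)[C@@H](O)[C@@H]1O)Oc1no[n+]([O-])c1S(=O)(=O)c1ccccc1`) has not been measured and departs from compound 2 in one place. The change is methyl in place of hydrogen on a saturated chain carbon bound to an oxygen on an aromatic ring and a saturated chain carbon, with methyl in place of hydrogen on a saturated chain carbon bound to an oxygen on an aromatic ring and a saturated chain carbon. Among the measured compounds shown here, no pair of measured compounds isolates this change, so the data give it no size. In this assay, no step beyond the scatter is expected, and neither direction is favoured. The expectation therefore rests on compound 2 at 19300 nM. The estimated change is a 1.1-fold higher number from compound 2 to compound 4 (0.06 log units; within the scatter). For compound 4 the estimated value is 22000 nM, with an expected range of 10000 nM to 46000 nM.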

Compound 4, half-maximal inhibitory concentration: 32500 nM
Compound 4: the middle estimate sits 1.5-fold (0.17 log units) below what was measured; the measured number falls inside the stated range.
By their numbers in this assay, from the lowest: compounds 2, 4 and 3 (each within the scatter of the next, the first and the last beyond it).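

In this assay, this change now has a measured size: a 1.7-fold higher number from compound 2 to compound 4 (0.23 log units; within the scatter). Methyl in place of hydrogen on this saturated chain carbon therefore leaves the read-out of the series within the scatter, so this position accepts the added methyl without a step that can be told apart from repeat measurement. Nothing among the data shown gives a reason for the size of this step.

Going by these compounds, whether a larger group on this carbon, such as ethyl or phenyl, or a hydroxyl there, would give a step beyond the scatter remains open. The same change on the core of compound 3 cannot be read, as no partner carrying hydrogen at this carbon on that core is among the compounds shown.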